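The source may report more compounds than this note shows. Statements on the series, on what has been measured and on what is new or still open speak of the compounds shown alone.

Measured so far in a functional assay on K562 cells (Homo sapiens) for antiproliferative activity, read by MTT assay, with a stated time of 48 h; on this read-out lower numbers stand for stronger inhibition and higher numbers for weaker inhibition:
Compound 1 `CCn1c(N)c(-c2nc3ccccc3[nH]2)c2nc(C#N)c(C#N)nc21`: > 50000 nM
Compound 2 `N#Cc1nc2c(-c3nc4ccccc4[nH]3)c(N)n(CCO)c2nc1C#N`: > 50000 nM

In this assay compound 2 gives > 50000 nM, which is a limit and not a number. Compound 1 gives > 50000 nM, which is also a limit. The whole record so far is thus (the limit of > 50000 nM in this assay, at which 2 of the 2 values shown sit).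

Compound 3 `CCCCn1c(N)c(-c2nc3ccccc3[nH]2)c2nc(C#N)c(C#N)nc21` differs from compound 2 by one change, ethyl in place of hydroxy on a saturated chain carbon, two bonds along the chain from an aromatic nitrogen. Cut one bond further out, this is butyl in place of 2-hydroxyethyl.

Going by the values given here, the only measured step that bears on it is a step that the two limits leave unreadable from compound 1 to compound 2, with hydroxy in place of hydrogen on that same carbon. That step has no readable size, so it offers nothing to carry over. A result at the same limit in this assay remains likely, and any move is expected toward stronger inhibition, since compound 2 stands at a limit.

The expected change is an at least 1.4-fold lower number from compound 2 to compound 3 (0.15 log units; that floor lies within the scatter). The estimate for compound 3 is 35000 nM, with an expected range from 8000 nM to 70000 nM.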

Compound 3, half-maximal inhibitory concentration: > 50000 nM
Compound 3: a limit, no number; the forecaster's own chance of this, stated with the estimate: 60%; at least 1.4-fold (0.15 log units) between middle value and limit.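

No new step can be read from this result: the steps from compound 1 to compound 3 and from compound 2 to compound 3 both run between limits. The compounds shown leave open whether hydrogen, hydroxy or ethyl on that saturated chain carbon makes any difference in this assay, and the record ends at a single limit: the limit of > 50000 nM in this assay, at which 3 of the 3 values shown sit.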